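A Smaller Acetylated Ring on the Amide-Type Nitrogen

The source may report more compounds than this note shows. Statements on the series, on what has been measured and on what is new or still open speak of the compounds shown alone.

Within the data shown here, in a physicochemical assay for solubility, read by spectrophotometry, measured as kinetic solubility, at pH 8, tested at 500 uM (on this read-out lower numbers stand for lower solubility and higher numbers for higher solubility), compound 1 (`CNC(=O)c1ccncc1Nc1cc(-c2ccc3ccn(C)c3c2)c2nccnc2c1`) reads 4 ug/mL and compound 2 (`CC(=O)N1CCCC(NC(=O)c2ccncc2Nc2cc(-c3ccc4ccn(C)c4c3)c3nccnc3c2)C1`) reads 212 ug/mL so compound 2 holds the higher of the only two numbers available. Among the measured compounds shown here, the single measured step is a 53-fold higher number from compound 1 to compound 2 (1.72 log units; beyond the scatter) and it comes with 1-acetylpiperidin-3-yl in place of methyl on an amide-type nitrogen.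

Compound 3 (`CC(=O)N1CC(NC(=O)c2ccncc2Nc2cc(-c3ccc4ccn(C)c4c3)c3nccnc3c2)C1`) alters that same substituent again, and the rest of the structure stays as in compound 2. The change is 1-acetylazetidin-3-yl in place of 1-acetylpiperidin-3-yl on an amide-type nitrogen and it is the only difference. For the measured compounds named here, no measured compound yet carries the four-membered ring, so the one step available bears on this change only loosely. That step, a 53-fold higher number from compound 1 to compound 2 (1.72 log units; beyond the scatter) was large, but it started from methyl. Compound 3 keeps a 1-acetyl ring group in that place, so a far smaller change is expected, with a slight fall in this assay as the likelier direction. The expected step is a 1.2-fold lower number from compound 2 to compound 3 (0.10 log units; within the scatter) and none beyond the scatter is anticipated. Thus in this assay compound 3 is estimated at 170 ug/mL with an expected range of 70 ug/mL to 260 ug/mL as its bounds.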

Compound 3, solubility: 244 ug/mL
Compound 3: the middle estimate sits 1.4-fold (0.16 log units) below what was measured; low and high end bracket the measured number.
By their numbers in this assay, from the lowest: compound 1; then compounds 2 and 3 (each within the scatter of the next).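

In this assay, exchanging the six-membered ring for the four-membered one gives a 1.2-fold higher number from compound 2 to compound 3 (0.06 log units; within the scatter), so on this read-out compound 2 and compound 3 cannot be told apart. Among these compounds, this is the first comparison of two acetylated rings on the amide-type nitrogen, and it shows that ring size, across these two groups, leaves the number within the scatter. Placing 1-acetylazetidin-3-yl where compound 1 has methyl gives a 61-fold higher number from compound 1 to compound 3 (1.79 log units; beyond the scatter), so the large step first seen with 1-acetylpiperidin-3-yl now appears with a second ring group, one with the smaller heavy-atom count. No accompanying measurement helps to explain these numbers.

Both ring groups carry the acetyl on the ring nitrogen, so the compounds shown leave open how much of the large step depends on that acetyl, and whether a free azetidine amine or a methylsulfonyl group on the same ring nitrogen would read alike. They also leave open whether the ring itself matters at all, or whether an open chain such as 2-acetamidoethyl on the amide-type nitrogen would read like compound 2 and compound 3.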